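Series notes: compound 4 against compound 2

This account rests on a few compounds, and the source may have more. Where it says the series, first, only, none or still open, it means among the compounds named here.

Measured compounds:
- compound 1 `COc1cc(OC)c(/C=C(/C(=O)c2ccc(Cl)cc2)S(=O)(=O)Cc2ccccc2Cl)c(OC)c1`; in a functional assay on DU-145 cells (Homo sapiens) for inhibition, read by trypan blue exclusion, with a stated time of 96 h (a higher number here means a weaker inhibitor of growth, a lower number a stronger inhibitor of growth), compound 1 gives > 100000 nM, which is a limit of the assay, not a number.
- compound 2 `Cc1ccc(CS/C(=C/c2ccccc2F)C(=O)c2ccc(Cl)cc2)cc1`; in this assay compound 2 gives 10000 nM.
- compound 3 `Cc1ccc(CS/C(=C/c2ccccc2OCc2ccccc2)C(=O)c2ccc(Cl)cc2)cc1`; in this assay compound 3 gives 1000 nM.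

Among the measured compounds shown here, compound 2 stands highest of the two numbers; its nearest neighbour is compound 3, and the one measured step, a 10-fold lower number from compound 2 to compound 3 (1.00 log units; beyond the scatter), is beyond the scatter. For the measured compounds named here, compound 1 sits at the limit of > 100000 nM in this assay, at which 1 of the 3 values shown sits, so it gives no step.

Compound 4 `Cc1ccc(CS/C(=C/c2cccc(Cl)c2Cl)C(=O)c2ccc(Cl)cc2)cc1` differs from compound 2 by 2,3-dichlorophenyl in place of 2-fluorophenyl on a double-bonded chain carbon bound to a double-bonded chain carbon. Going by the values given here, the only measured step bearing on this place is the change from compound 2 to compound 3, where benzyloxy in place of fluoro on an aromatic carbon lowered the number. The change to compound 4 touches the same carbon-only aromatic ring but brings a different group, so the size of that step cannot be carried over directly; a smaller lowering is expected, a 2.0-fold lower number from compound 2 to compound 4 (0.30 log units; within the scatter). Compound 4 is therefore estimated at 5000 nM in this assay, within 1500 nM to 20000 nM.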

Compound 4, concentration for 50% growth inhibition: 25000 nM
Estimate against measurement, compound 4: 5.0-fold (0.70 log units) below; the measured number lies above the stated range.
By their numbers in this assay, from the lowest: compound 3; then compound 2; then compound 4. At a limit, above all of these: compound 1.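

In this assay the aryl group on the double-bonded chain carbon can move the number either way: 2,3-dichlorophenyl gives a 2.5-fold higher number from compound 2 to compound 4 (0.40 log units; beyond the scatter), against a 10-fold lower number from compound 2 to compound 3 (1.00 log units; beyond the scatter) with the benzyloxy group. Replacing 2-fluorophenyl at this place therefore does not lower the number in every case, and compound 4 goes against any such reading of compound 3. Nothing measured among these compounds accounts for the direction of the step to compound 4.

On these data alone, it remains open whether a phenyl ring bearing a single chlorine would read nearer to compound 2 or to compound 4. As far as these compounds go, it is also open whether a methoxy group or an amine in place of the fluoro would follow benzyloxy in lowering the number.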